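A Second Methyl on the Saturated Ring of Compound 1

A few compounds are considered here, and "the series" means these few. Any claim that something is new, unique, unknown or untested is made for them only; others in the source may bear on it.

Compound 1 `C[C@@H]1Cc2cc(C(N)=O)cnc2N1` holds the lower of the two numbers measured in an assay on K562 cells for inhibition of Nicotinamide N-methyltransferase (Homo sapiens), read by mass spectrometry, with a stated time of 24 h; on this read-out higher numbers stand for weaker inhibition and lower numbers for stronger inhibition: in this assay compound 1 gives 38 nM. Going by the values given here, its only measured neighbour, compound 2 `NC(=O)c1cnc2c(c1)CCN2`, gives 142 nM in this assay, and the step of a 3.7-fold higher number from compound 1 to compound 2 (0.57 log units; beyond the scatter) shows that taking the methyl off the saturated ring carbon weakens inhibition. Compound 3 `C[C@H]1Nc2ncc(C(N)=O)cc2[C@@H]1C` has not yet been measured; it differs from compound 1 by methyl in place of hydrogen on a saturated ring carbon. The step from compound 1 to compound 2 is the only one that bears on this change, and it concerns removal rather than addition of a methyl, so it gives direction only loosely. The author therefore expects no step beyond the scatter in this assay, with a small chance of either direction. For compound 3 the estimate is 45 nM, within 15 nM to 150 nM, which is expected to mean a 1.2-fold higher number from compound 1 to compound 3 (0.07 log units; within the scatter).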

Compound 3, half-maximal inhibitory concentration: 114 nM
Compound 3: middle estimate off by 2.5-fold (0.40 log units), on the low side, and the stated range covers the measured number.
By their numbers in this assay, from the lowest: compound 1; then compounds 3 and 2 (each within the scatter of the next).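

The carbon next to the ring atom that bears a methyl group now proves sensitive to substitution: methyl in place of hydrogen there gives a 3.0-fold higher number from compound 1 to compound 3 (0.48 log units; beyond the scatter) in this assay, so the added methyl weakens inhibition. Until now, the only step at a saturated ring carbon was the removal of a methyl, and that too raised the number, giving a 3.7-fold higher number from compound 1 to compound 2 (0.57 log units; beyond the scatter); among these three compounds, a change in either direction from compound 1 therefore costs inhibition. No evidence is available to explain why the second methyl has this effect.

The compounds shown leave open how a methyl on this carbon would read without the neighbouring methyl. They also leave open whether an ethyl group, a hydroxyl group or a fluorine atom there would behave as the methyl does.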